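Swapping a small saturated ring for a methylpyrazole

The source may hold more compounds than are shown below. What is called first, only, known or untested is meant among the compounds shown, and "the series" means these compounds.

The compounds share one core, an amide built from a dimethoxypyridine methylamine and a pyridine carboxylic acid that carries a 5-methylpyridin-3-yl group. They were tested in an assay on CHO cells for displacement of a labelled ligand from Orexin receptor type 2 (Homo sapiens), read by scintillation counting, with a stated time of 3 h; on this read-out lower numbers stand for stronger inhibition and higher numbers for weaker inhibition. Compound 1 `COc1ccc(CNC(=O)c2cc(-c3cncc(C)c3)ncc2-c2cncc(F)c2)nc1OC` gives 5.2 nM. Compound 2 `COc1ccc(CNC(=O)c2cc(-c3cncc(C)c3)ncc2N2CCC2)nc1OC`, which carries an azetidin-1-yl group, gives 10 nM, the highest of the three numbers measured. Compound 3 `COc1ccc(CNC(=O)c2nc(-c3cncc(C)c3)cnc2-c2ccccc2)nc1OC`, built on a differently arranged core with a phenyl group, gives 1.4 nM, a lower number than that of compound 2 and beyond the scatter.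

Compound 4 `COc1ccc(CNC(=O)c2cc(-c3cncc(C)c3)ncc2-c2cnn(C)c2)nc1OC` differs from compound 2 in one place: 1-methyl-1H-pyrazol-4-yl in place of azetidin-1-yl on an aromatic carbon.

Going by the values given here, only one measured step speaks to this change. From compound 1 to compound 2 the azetidin-1-yl group replaced a 5-fluoropyridin-3-yl group and gave a 1.9-fold higher number from compound 1 to compound 2 (0.28 log units; within the scatter). Compound 4 restores an aromatic ring at the same place, though a smaller five-membered one, so compound 4 is expected to land near compound 1 rather than far from compound 2, and the step of a 1.7-fold lower number from compound 2 to compound 4 (0.22 log units; within the scatter) is expected to stay within or just at the edge of the scatter.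

On this basis compound 4 is estimated at 6 nM, with a likely range from 2 nM to 18 nM.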

Compound 4, inhibition constant: 4.1 nM
Compound 4: the middle estimate sits 1.5-fold (0.17 log units) above what was measured, and the stated range covers the measured number.
By their numbers in this assay, from the lowest: compound 3; then compounds 4, 1 and 2 (each within the scatter of the next, the first and the last beyond it).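

In this assay the change to 1-methyl-1H-pyrazol-4-yl gives a 2.4-fold lower number from compound 2 to compound 4 (0.39 log units; beyond the scatter) and is a modest but real shift at this position, whereas the earlier step between the azetidin-1-yl and 5-fluoropyridin-3-yl groups stayed within the scatter. The two aromatic groups cannot be told apart on this read-out, as the step of a 1.3-fold lower number from compound 1 to compound 4 (0.10 log units; within the scatter) also lies within the scatter, so the five-membered ring does as well here as the six-membered one. Going by these compounds alone, compound 1 keeps this from being a clean rule that any aromatic ring beats azetidin-1-yl, since only the step from compound 2 to compound 4 clears the scatter, and nothing at hand explains the shift.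

The compounds shown leave open whether an open-chain amine such as dimethylamino, or a larger saturated ring such as morpholine, would behave like azetidin-1-yl or like the aromatic groups at this place. They also leave open how a phenyl group would read on the shared core of compounds 1, 2 and 4, as compound 3 differs from them in more than one place and cannot be compared directly.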